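The source may hold more compounds than are shown below. What is called first, only, known or untested is meant among the compounds shown, and "the series" means these compounds.

The compounds measured in an assay on isolated protein for inhibition of lysosomal alpha-glucosidase (Rattus norvegicus), read by colorimetric assay; a lower number here means a stronger inhibitor, a higher number a weaker inhibitor:
compound 1, `COc1ccc([C@]2(CO)NC[C@@H](O)[C@@H]2O)cc1`, 395000 nM
compound 2, `C[C@]1(CO)NC[C@@H](O)[C@@H]1O`, 830 nM
compound 3, `C[C@@]1(CO)NC[C@H](O)[C@H]1O`, 2900 nM

Compound 1 gives the highest number of the three and is the weakest inhibitor of this set; compounds 2 and 3 lie far lower. For the measured compounds named here, the only step between measured compounds is a 3.5-fold higher number from compound 2 to compound 3 (0.54 log units; beyond the scatter), a change that goes back to the fact that compounds 2 and 3 differ only in the configuration as drawn and concerns the ring configuration rather than the aryl substituent. Compound 4, `OC[C@@]1(c2ccc(F)cc2)NC[C@@H](O)[C@@H]1O`, differs from compound 1 by fluoro in place of methoxy on an aromatic carbon. Going by the values given here, no measured step bears on this change, so the expectation rests on compound 1 alone, and the step in this assay is expected to stay within the scatter. For compound 4 the estimated value is 350000 nM, between 120000 nM and 1000000 nM, an expected 1.1-fold lower number from compound 1 to compound 4 (0.05 log units; within the scatter).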

Compound 4, half-maximal inhibitory concentration: 12000 nM
Compound 4: the middle estimate sits 29-fold (1.46 log units) above what was measured; measured number outside the range, below it.
By their numbers in this assay, from the lowest: compound 2; then compound 3; then compound 4; then compound 1.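

Fluoro in place of methoxy on an aromatic carbon gives a 33-fold lower number from compound 1 to compound 4 (1.52 log units; beyond the scatter) in this assay. This shows that the group at this place, para to a group of 9 heavy atoms, has a large bearing on the number, which compound 1 alone could not show. Nothing given here accounts for this step. The compounds shown leave open whether the lower number goes with the loss of methoxy or with the presence of fluoro. They also leave open what chloro, hydroxyl or a plain hydrogen at the same place would give.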